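The source may hold more compounds than are shown below. What is called first, only, known or untested is meant among the compounds shown, and "the series" means these compounds.

Working notes on the series. In a functional assay on K562 cells (Homo sapiens) for antiproliferative activity, with a stated time of 72 h (a lower number here means a stronger inhibitor, a higher number a weaker inhibitor), compound 1 `OC[C@H]1O[C@@H](n2cnc3c(NCc4ccccc4Br)ncnc32)[C@H](O)[C@@H]1O` gives 10000 nM and compound 3 `OC[C@H]1O[C@@H](n2cnc3c(NCc4ccc(F)cc4F)ncnc32)[C@H](O)[C@@H]1O` gives 9600 nM; the step of a 1.0-fold lower number from compound 1 to compound 3 (0.02 log units; within the scatter) lies within the scatter, so the two sit together. Compound 2 `COc1cccc(CNc2ncnc3c2ncn3[C@@H]2O[C@H](CO)[C@@H](O)[C@H]2O)c1` reaches only a limit of this assay, > 166000 nM, the line the limit of > 166000 nM in this assay, at which 1 of the 3 values shown sits, marking where it sits. The steps of an at least 16-fold higher number from compound 1 to compound 2 (1.22 log units; beyond the scatter) and an at least 17-fold lower number from compound 2 to compound 3 (1.23 log units; beyond the scatter) are the only large movements seen, and both run between the 3-methoxyphenyl of compound 2 and the other two groups.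

Compound 4 `OC[C@H]1O[C@@H](n2cnc3c(NCc4cccc(C(F)(F)F)c4)ncnc32)[C@H](O)[C@@H]1O` is not yet measured in this assay. Its change from compound 3 is 3-(trifluoromethyl)phenyl in place of 2,4-difluorophenyl on a saturated chain carbon bound to a nitrogen on an aromatic ring. Among the measured compounds shown here, neither measured step covers a 3-(trifluoromethyl)phenyl; the nearest precedent is the large step of an at least 17-fold lower number from compound 2 to compound 3 (1.23 log units; beyond the scatter), in which a 3-methoxyphenyl left and a 2,4-difluorophenyl entered. Given that, compound 4 is expected to give a somewhat higher number than compound 3, with the step of a 3.1-fold higher number from compound 3 to compound 4 (0.49 log units; beyond the scatter) expected beyond the scatter but uncertain in size. The estimate for compound 4 in this assay is 30000 nM, expected between 7000 nM and 166000 nM, with a fair chance that only a limit is reported.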

Compound 4, half-maximal inhibitory concentration: > 166000 nM
Compound 4: only a limit was reported (the forecaster's own chance of this, stated with the estimate: 30%); middle value at least 5.5-fold (0.74 log units) from the limit.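

In this assay, the large steps of an at least 17-fold higher number from compound 3 to compound 4 (1.23 log units; beyond the scatter) and an at least 16-fold higher number from compound 1 to compound 4 (1.22 log units; beyond the scatter) show that the collapse seen with the 3-methoxyphenyl of compound 2 is not confined to that group, since a 3-(trifluoromethyl)phenyl on the same saturated chain carbon also leaves the measurable range. The step between compound 2 and compound 4 cannot be read, as both values are limits. The series now divides, with no compound shown going against the division: the 2-bromophenyl and 2,4-difluorophenyl compounds give numbers, while both 3-substituted phenyl compounds stand at a limit: the limit of > 166000 nM in this assay, at which 2 of the 4 values shown sit.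

The compounds shown do not separate the place of the substituent on the phenyl from its identity. As far as these compounds go, how an unsubstituted phenyl, a phenyl carrying an amine or a carboxylic acid, or a longer chain to the ring would read remains open.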